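The compounds below may be only part of what the source reports. "The series", "measured", "known", "first", "only" and "open" are said of these compounds alone.

Two compounds have so far been measured in a functional assay on MDA-MB-231 cells (Homo sapiens) for inhibition, read by MTT assay, with a stated time of 72 h; on this read-out higher numbers stand for weaker inhibition and lower numbers for stronger inhibition:

- compound 1, `COc1cccc(NC(=O)CSc2nc(Nc3ccccc3)c3ccccc3n2)c1`, gives 21700 nM
- compound 2, `C=CC(=O)Nc1cccc(NC(=O)CSc2nc(Nc3ccccc3Cl)c3ccccc3n2)c1`, gives 12700 nM

Of the two numbers, compound 2 has the lower one, but its gap to compound 1 lies within the usual scatter of repeated measurements, so the two compounds cannot be told apart on these data. Compound 3, `C=CC(=O)Nc1cccc(NC(=O)CSc2nc(Nc3ccc(Cl)cc3Cl)c3ccccc3n2)c1`, is the next compound to be tested. It differs from compound 2 in one place: chloro in place of hydrogen on an aromatic carbon. For the measured compounds named here, no pair of measured compounds shows what this change does in this assay, so there is nothing to borrow from. The step from compound 2 to compound 3 is therefore expected to be small, a 1.3-fold lower number from compound 2 to compound 3 (0.10 log units; within the scatter), and not clearly beyond the scatter in either direction. On that basis compound 3 is estimated to give 10000 nM, with a range from 3500 nM to 30000 nM.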

Compound 3, half-maximal inhibitory concentration: 23100 nM
For compound 3 the middle estimate is 2.3-fold (0.36 log units) below the measured one; the measured number falls inside the stated range.
By their numbers in this assay, from the lowest: compounds 2, 1 and 3 (each within the scatter of the next).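

For the compounds shown here, the change from 2-chlorophenyl to 2,4-dichlorophenyl gives the first measured look at chloro on this ring carbon, para to a large group and meta to a chloro group. In this assay it amounts to a 1.8-fold higher number from compound 2 to compound 3 (0.26 log units; within the scatter), so this position takes a second chloro with no change that can be told apart from repeat-to-repeat variation. Nothing measured here bears on why the step is this size.

From the compounds shown here alone, it remains open whether a different group at this same place, such as fluoro, methoxy, an amine or a carboxylic acid, would move the number clearly beyond the scatter. The contribution of the chloro already present in compound 2 also stays unknown, as no pair of compounds shown isolates it.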